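Working notes: 4-aminophenyl to 3,4-difluorophenyl on the carbonyl

The source may hold more compounds than are shown below. What is called first, only, known or untested is meant among the compounds shown, and "the series" means these compounds.

Three compounds of the shared core have been run in a functional assay on A498 cells (Homo sapiens) for cytotoxicity, read by sulforhodamine B assay, with a stated time of 48 h, tested at 1 uM; on this read-out higher numbers stand for a weaker effect at the one concentration tested and lower numbers for a stronger effect. Compound 1 `COc1cc(-c2cc(/C=C/C(=O)c3ccc(N)cc3)[nH]n2)cc(OC)c1OC` gives 76%, compound 2 `COc1ccc(-c2cc(/C=C/C(=O)c3ccc(N)cc3)[nH]n2)cc1OC` gives 89% and compound 3 `COc1cc(C(=O)/C=C/c2cc(-c3cc(OC)c(OC)c(OC)c3)n[nH]2)cc(OC)c1OC` gives 80%. Compound 1 thus sits at the low end of the three numbers: its gap to compound 3 lies within the scatter, while the step of a number 13 percentage points higher from compound 1 to compound 2 (beyond the scatter) lies beyond it.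

Compound 4 `COc1cc(-c2cc(/C=C/C(=O)c3ccc(F)c(F)c3)[nH]n2)cc(OC)c1OC` differs from compound 1 by 3,4-difluorophenyl in place of 4-aminophenyl on a carbonyl carbon. For the measured compounds named here, none of the measured steps touches the ring on the carbonyl carbon: the only recorded step, a number 13 percentage points higher from compound 1 to compound 2 (beyond the scatter), is hydrogen in place of methoxy on an aromatic carbon elsewhere, and compound 3 carries its groups differently on the shared core rather than changing this ring. Going by the values given here, no measured step therefore bears directly on the change to compound 4, and in this assay no step beyond the scatter is expected in either direction.

For compound 4 the expected value in this assay is 80%, with a range from 60% to 98%. The expected step is accordingly a number 4 percentage points higher from compound 1 to compound 4 (within the scatter), estimated to fall within the usual scatter.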

Compound 4, a percentage reported as activity, at one concentration (the size of the read-out at that concentration, not a potency): 81%
Estimate against measurement, compound 4: 1 percentage points below; measured number inside the range.
By their numbers in this assay, from the lowest: compounds 1, 3, 4 and 2 (each within the scatter of the next, the first and the last beyond it).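

In this assay, the ring on the carbonyl carbon now has its first measured change, and exchanging 4-aminophenyl for 3,4-difluorophenyl gives a number 5 percentage points higher from compound 1 to compound 4 (within the scatter). The hydrogen-bond donor and acceptor counted on 4-aminophenyl are absent from 3,4-difluorophenyl, and the exchange still leaves the read-out at this one concentration unable to separate the two compounds, so for this pair neither the amine nor those counted donor and acceptor sites are needed to hold the number within the scatter. No measurement in hand speaks to the cause of this result.

From the compounds shown here alone, it remains open whether the same holds for quite different groups on this ring, such as a carboxylic acid, a nitrile or a morpholine, or for a carbonyl carbon carrying something other than a phenyl ring. Also open, going by these compounds, is whether the two groups would still be indistinguishable in a full concentration series rather than at a single concentration, and whether the exchange behaves the same way on the core of compound 2.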